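The compounds below may be only part of what the source reports. "The series", "measured", "known", "first", "only" and "open" are said of these compounds alone.

Three related compounds have been tested in a physicochemical assay for solubility, read by LC-MS, in phosphate buffer, with a stated time of 24 h, at pH 7.4 (on this read-out higher numbers stand for higher solubility and lower numbers for lower solubility), so far. Compound 1 (`CN(c1ncco1)c1cnc(NCc2c(F)ccc3c2CCO3)n2cnnc12`) gives 67000 nM and holds the second highest of the three numbers. Compound 3 (`CN(C)Cc1ccc(C(=O)Nc2cnc(NCc3c(F)ccc4c3CCO4)n3cnnc23)cc1`) gives 520000 nM and compound 2 (`Cn1nccc1-c1cnc(NCc2c(F)ccc3c2CCO3)c2cn[nH]c(=O)c12`) gives 2000 nM. The number of compound 3 is higher than that of compound 1 and the number of compound 2 is well lower, and both gaps lie beyond the usual scatter of repeated measurements.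

The next compound to be measured is compound 4 (`CC1(C)CC(=O)N(c2cnc(NCc3c(F)ccc4c3CCO4)n3cnnc23)C1`). It keeps the rest of compound 1 but carries 4,4-dimethyl-2-oxopyrrolidin-1-yl in place of methyl(1,3-oxazol-2-yl)amino on an aromatic carbon. In plain terms, a group with a five-membered aromatic ring leaves and a five-membered non-aromatic ring enters, with no net charge on either.

Within the data shown here, no two measured compounds differ in one place only, so nothing here sizes this swap directly. The three numbers also spread widely, which argues for caution. The expectation is therefore a slight fall at most, with no change beyond the scatter. The expected step is a 1.7-fold lower number from compound 1 to compound 4 (0.22 log units; within the scatter) in this estimate. For compound 4 the estimated value is 40000 nM with an expected range from 9000 nM to 180000 nM on this read-out.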

Compound 4, solubility: 57000 nM
Compound 4: the middle estimate sits 1.4-fold (0.15 log units) below what was measured; measured number inside the range.
By their numbers in this assay, from the lowest: compound 2; then compounds 4 and 1 (each within the scatter of the next); then compound 3.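

In this assay, among these compounds, the first step that can be read at this position, an aromatic carbon of a six-membered aromatic ring with 2 nitrogen, is a 1.2-fold lower number from compound 1 to compound 4 (0.07 log units; within the scatter), with 4,4-dimethyl-2-oxopyrrolidin-1-yl in place of methyl(1,3-oxazol-2-yl)amino. The two groups are far from identical, since one five-membered aromatic ring with 2 hetero atoms and 3 hydrogen-bond acceptors gives way to one five-membered non-aromatic ring with 1 hetero atom and 1 hydrogen-bond acceptor, yet this read-out does not separate them. No measurement shown here explains why the two groups give such close numbers.

This single pair leaves open whether a simple amine, a carboxylic acid or a longer alkyl chain on the same aromatic carbon would also stay within the scatter of compound 1 or would move the number beyond it. It also leaves open whether the same exchange of groups would give a similar step on a different core.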